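A few compounds are considered here, and "the series" means these few. Any claim that something is new, unique, unknown or untested is made for them only; others in the source may bear on it.

Measured in an assay on CHO cells for displacement of a labelled ligand from adenosine receptor A3 (Homo sapiens), tested at 10 uM; on this read-out higher numbers stand for more inhibition at the one concentration tested (going by the name of the read-out) and lower numbers for less inhibition:
compound 1 `O=C1CCCc2[nH]c(=O)c(C(=O)c3ccccc3)cc21` gives 0%
compound 2 `O=C1CC(c2ccccc2)Cc2[nH]c(=O)c(C(=O)c3ccccc3)cc21` gives 0%
compound 3 `CC(=O)c1cc(S(=O)(=O)c2ccccc2)c(=O)[nH]c1C` gives 0%

Compound 1 stands level with compounds 2 and 3 at the digits shown; the nearest, compound 2, and the furthest, compound 3, both lie within the scatter of it. Among the measured compounds shown here, the only single-point step in the set, no change at the digits printed from compound 1 to compound 2 (within the scatter), alters a saturated ring carbon and does not touch the carbonyl substituent. Compound 3 differs in several places at once, so only its value speaks.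

Compound 4 `CC(C)(C)C(=O)c1cc2c([nH]c1=O)CCCC2=O` differs from compound 1 by tert-butyl in place of phenyl on a carbonyl carbon. For the measured compounds named here, no measured step bears on this change; every compound sits at the floor of the read-out. The step is therefore expected to be none beyond the scatter, no change at the digits printed from compound 1 to compound 4 (within the scatter). Compound 4 is estimated at 0% (range 0% to 12%).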

Compound 4, a percentage reported as inhibition, at one concentration (the size of the read-out at that concentration, not a potency): 0%
The estimate for compound 4 equals the measured number at the digits printed, and the stated range covers the measured number.
By their numbers in this assay, from the lowest: compounds 1, 2, 3 and 4 (each within the scatter of the next).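

The step at the carbonyl carbon, tert-butyl in place of phenyl, gives in this assay (no change at the digits printed from compound 1 to compound 4 (within the scatter)), so the aromatic ring on that carbon is not needed to hold the value where it stands. With both groups the read-out sits at its floor, so this position gives no ranking of phenyl against tert-butyl. No evidence on the origin of this result is available.

Open, from the compounds shown here alone, is whether any group on this carbonyl carbon lifts the read-out from the floor, for example a longer chain ending in an amine or a carboxylic acid.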